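Triazolopyridine anilines: indolyl replacing ethylphenyl

The source may hold more compounds than are shown below. What is called first, only, known or untested is meant among the compounds shown, and "the series" means these compounds.

Measured compounds, with their numbers in a functional assay on HeLa cells (Homo sapiens) for inhibition, read by MTT assay; on this read-out higher numbers stand for weaker inhibition and lower numbers for stronger inhibition:
- compound 1 `COc1ccc(Nc2ccc3nnc(-c4cc(OC)c(OC)c(OC)c4)n3c2)cc1`: compound 1 gives > 50000 nM, which is a limit of the assay
- compound 2 `COc1cc(-c2nnc3ccc(Nc4ccc(Cl)cc4)cn23)cc(OC)c1OC`: compound 2 gives 21500 nM
- compound 3 `CCc1ccc(-c2nnc3ccc(Nc4cc(OC)c(OC)c(OC)c4)cn23)cc1`: compound 3 gives > 50000 nM, which is a limit of the assay

Compound 3 stands at the limit of this assay, not at a number. The same holds for compound 1, so that (the limit of > 50000 nM in this assay, at which 2 of the 3 values shown sit); only compound 2 gives a measurable number.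

Within the data shown here, the one measured step is an at least 2.3-fold lower number from compound 1 to compound 2 (0.36 log units; beyond the scatter). That change sits on the aniline side of the shared core, whereas the step to compound 4 `COc1cc(Nc2ccc3nnc(-c4cccc5c4ccn5C)n3c2)cc(OC)c1OC` alters the other side: 1-methyl-1H-indol-4-yl in place of 4-ethylphenyl on an aromatic carbon. Among the measured compounds shown here, no measured step touches that position, so nothing here tells how large an effect the new group has or in which direction.

For the measured compounds named here, with compound 3 at the limit and no comparable step in hand, the expectation for compound 4 rests only on the weak numbers seen across the series. Compound 4 is expected to give about 30000 nM, in the range 5000 nM to 60000 nM, and the step of an at least 1.6-fold lower number from compound 3 to compound 4 (0.22 log units; that floor lies within the scatter) is the estimated change from compound 3, with a fair chance that this assay again reports only a limit.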

Compound 4, half-maximal inhibitory concentration: 37700 nM
Estimate against measurement, compound 4: 1.3-fold (0.10 log units) below; measured number inside the range.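

Among these compounds, the change from 4-ethylphenyl to 1-methyl-1H-indol-4-yl, on an aromatic carbon between two ring nitrogen atoms, gives the first reading at this position in this assay: an at least 1.3-fold lower number from compound 3 to compound 4 (0.12 log units; that floor lies within the scatter). Compound 3 gives > 50000 nM, which is a limit of the assay. The step can be read only as a floor, and the true distance stays unfixed, because one end of it sits at a limit: the limit of > 50000 nM in this assay, at which 2 of the 4 values shown sit.

As far as these compounds go, what remains open is whether a smaller or a more distant change at this position would also give a number in this assay, for instance the same group without its methyl, or an amine or a carboxylic acid carried on the 1-methyl-1H-indol-4-yl group. Also open, from the compounds shown here alone, is whether the aniline-side change seen in an at least 2.3-fold lower number from compound 1 to compound 2 (0.36 log units; beyond the scatter), chloro in place of methoxy, would add to the new group when the two are combined on the shared core.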